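Compound 2 to compound 3: one fluoro fewer

A few compounds are considered here, and "the series" means these few. Any claim that something is new, unique, unknown or untested is made for them only; others in the source may bear on it.

In a functional assay on K562 cells (Homo sapiens) for inhibition, read by trypan blue exclusion, with a stated time of 72 h (on this read-out lower numbers stand for stronger inhibition and higher numbers for weaker inhibition), compound 1 `Cn1c(=O)c(S(=O)(=O)c2ccc(F)cc2)cc2cnc(Nc3ccc4occc4c3)nc21` gives 5000 nM and compound 2 `Cn1c(=O)c(S(=O)(=O)c2ccc(F)cc2F)cc2cnc(Nc3ccc4[nH]ncc4c3)nc21` gives 50000 nM. Compound 2 thus holds the higher of the two numbers, a gap beyond the scatter. Compound 3 `Cn1c(=O)c(S(=O)(=O)c2ccc(F)cc2)cc2cnc(Nc3ccc4[nH]ncc4c3)nc21` comes from compound 2 by hydrogen in place of fluoro on an aromatic carbon, so 2,4-difluorophenyl becomes 4-fluorophenyl. Among the measured compounds shown here, no measured pair isolates this change, so only a small move toward lower numbers in this assay is expected, near the scatter. The estimated change is a 2.0-fold lower number from compound 2 to compound 3 (0.30 log units; within the scatter). For compound 3 the estimated value is 25000 nM, with an expected range of 7000 nM to 60000 nM.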

Compound 3, half-maximal inhibitory concentration: 10000 nM
For compound 3 the middle estimate is 2.5-fold (0.40 log units) above the measured one, and the stated range covers the measured number.
By their numbers in this assay, from the lowest: compounds 1 and 3 (each within the scatter of the next); then compound 2.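

In this assay, the change from 2,4-difluorophenyl to 4-fluorophenyl gives a 5.0-fold lower number from compound 2 to compound 3 (0.70 log units; beyond the scatter), the first single-place reading showing that fluoro versus hydrogen at this position, ortho to a large group, matters in this series. With 4-fluorophenyl held constant, 1H-indazol-5-yl in place of 1-benzofuran-5-yl gives a 2.0-fold higher number from compound 1 to compound 3 (0.30 log units; within the scatter), so these two groups are not separated on this read-out. Nothing available explains either step.

Open, on these data alone, is how chloro, methoxy or an amine at this position would read against hydrogen and fluoro. Also open, as far as these compounds go, is whether the remaining fluoro contributes, as a comparison with unsubstituted phenyl would show.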